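A few compounds are considered here, and "the series" means these few. Any claim that something is new, unique, unknown or untested is made for them only; others in the source may bear on it.

Measured in a functional assay on B16-F10 cells (Mus musculus) for antiproliferative activity, read by MTT assay, with a stated time of 48 h; on this read-out lower numbers stand for stronger inhibition and higher numbers for weaker inhibition:
- compound 1 `Cc1ccc(NCc2cn(-c3ccccc3)nc2-c2ccc(Cl)cc2)cc1`: 3480 nM
- compound 2 `COc1ccc(-c2nn(-c3ccccc3)cc2CNc2ccc(C)cc2)cc1`: 8380 nM
- compound 3 `Cc1ccc(NCc2cn(-c3ccccc3)nc2-c2ccc(C)cc2)cc1`: 7380 nM

Compound 1 has the lowest number of the three. Compound 4 `Clc1ccc(NCc2cn(-c3ccccc3)nc2-c2ccc(Cl)cc2)cc1` keeps the core of compound 1 and differs by chloro in place of methyl on an aromatic carbon, para to a large group. Going by the values given here, no measured step touches the 4-methylphenyl group itself. The closest guide is a 2.1-fold higher number from compound 1 to compound 3 (0.33 log units; beyond the scatter), which swaps the same two groups in the opposite sense on another aromatic carbon. a 2.4-fold higher number from compound 1 to compound 2 (0.38 log units; beyond the scatter) is of similar size. A modest change toward a lower number is therefore expected, with the estimated step being a 1.4-fold lower number from compound 1 to compound 4 (0.14 log units; within the scatter), though the transfer between sites is uncertain. For compound 4 the estimated value is 2500 nM, with an expected range of 1000 nM to 6000 nM.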

Compound 4, half-maximal inhibitory concentration: 2450 nM
Estimate against measurement, compound 4: 1.0-fold (0.01 log units) above, and the stated range covers the measured number.
By their numbers in this assay, from the lowest: compounds 4 and 1 (each within the scatter of the next); then compounds 3 and 2 (each within the scatter of the next).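

In this assay the change of 4-methylphenyl to 4-chlorophenyl gives a 1.4-fold lower number from compound 1 to compound 4 (0.15 log units; within the scatter) and so stays within the scatter. The same two groups exchanged in the opposite sense on the other aromatic carbon give a 2.1-fold higher number from compound 1 to compound 3 (0.33 log units; beyond the scatter) and lie beyond it, so a step beyond the scatter at that site does not carry over to this position. Nothing available bears on a reason for this result. As far as these compounds go, whether a nitrile, an amine or a carboxylic acid in place of chloro at this position would move the number beyond the scatter remains open.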